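From fluoromethyl to bromo on the shared core

This account rests on a few compounds, and the source may have more. Where it says the series, first, only, none or still open, it means among the compounds named here.

In an ADME assay on HEp-2 cells (Homo sapiens) for cytotoxicity (a higher number here means that more compound is tolerated, a lower number that less compound is tolerated), compound 1 (`CNCc1ccc2c(c1)nc(Cn1c(=O)n(C(C)C)c3ccccc31)n2CCC(C)C`) gives 1480 nM, compound 2 (`CC(C)CCn1c(Cn2c(=O)n(C(C)C)c3ccccc32)nc2cc(CNS(C)(=O)=O)ccc21`) gives 30800 nM and compound 3 (`CC(C)CCn1c(Cn2c(=O)n(C(C)C)c3ccccc32)nc2cc(CF)ccc21`) gives 37300 nM. Compound 3 therefore stands level with compound 2 at the top of this small set, and well clear of compound 1. The measured steps show this pattern: a 21-fold higher number from compound 1 to compound 2 (1.32 log units; beyond the scatter) and a 25-fold higher number from compound 1 to compound 3 (1.40 log units; beyond the scatter) are both large, whereas a 1.2-fold higher number from compound 2 to compound 3 (0.08 log units; within the scatter) stays within the scatter.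

Compound 4 (`CC(C)CCn1c(Cn2c(=O)n(C(C)C)c3ccccc32)nc2cc(Br)ccc21`) differs from compound 3 as follows: bromo in place of fluoromethyl on an aromatic carbon. In words, it has bromo in place of fluoromethyl on an aromatic carbon. Among the measured compounds shown here, no measured step makes this exact change, so the evidence is indirect. Compound 4 lacks the methylamino group of compound 1 and is therefore expected to stay close to compound 3 at 37300 nM. In this assay, no shift beyond the scatter is expected, the estimated step being a 1.2-fold lower number from compound 3 to compound 4 (0.09 log units; within the scatter). For compound 4 the estimated value is 30000 nM, with an expected range of 12000 nM to 70000 nM.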

Compound 4, half-maximal cytotoxic concentration: 18100 nM
Beside the measured number, compound 4's estimate is 1.7-fold (0.22 log units) above it; low and high end bracket the measured number.
By their numbers in this assay, from the lowest: compound 1; then compounds 4, 2 and 3 (each within the scatter of the next, the first and the last beyond it).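

In this assay the change is made directly on the aromatic carbon, and bromo, a single heavy atom with no saturated chain carbon, replaces fluoromethyl with only a modest step (a 2.1-fold lower number from compound 3 to compound 4 (0.31 log units; beyond the scatter)). The step from the (methanesulfonamido)methyl group stays within the scatter (a 1.7-fold lower number from compound 2 to compound 4 (0.23 log units; within the scatter)), while the step from the (methylamino)methyl group remains large (a 12-fold higher number from compound 1 to compound 4 (1.09 log units; beyond the scatter)), so compound 4 joins compounds 2 and 3 well away from compound 1. No measured evidence accompanies these numbers to explain them.

On these data alone, whether the low number of compound 1 belongs to its methylamino group alone remains open, as no other amine, such as dimethylamino, appears at this aromatic carbon. Nor do the compounds shown tell how chloro or a carboxylic acid would read at this place.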